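A few compounds are considered here, and "the series" means these few. Any claim that something is new, unique, unknown or untested is made for them only; others in the source may bear on it.

Values from a functional assay on LNCaP cells (Homo sapiens) for cytotoxicity, read by sulforhodamine B assay, with a stated time of 72 h; on this read-out lower numbers stand for stronger inhibition and higher numbers for weaker inhibition:
- compound 1 `COc1cc(/C=C/C(=O)/C=C(O)/C=C/c2ccc(OC(C)(C)C(=O)Nc3ccc([N+](=O)[O-])c(C(F)(F)F)c3)c(OC)c2)ccc1O`: > 100000 nM (a limit)
- compound 2 `COc1cc(/C=C/C(=O)/C=C(O)/C=C/c2ccc(OC(C)(C)C(=O)Nc3ccc(F)c(C(F)(F)F)c3)c(OC)c2)ccc1O`: 54800 nM
- compound 3 `COc1ccc(/C=C/C(=O)/C=C(O)/C=C/c2ccc(OC(C)(C)C(=O)Nc3ccc([N+](=O)[O-])c(C(F)(F)F)c3)c(OC)c2)cc1OC`: > 100000 nM (a limit)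

Compound 3 has no number, only (the limit of > 100000 nM in this assay, at which 2 of the 3 values shown sit). The next compound is compound 4 `COc1ccc(/C=C/C(=O)/C=C(O)/C=C/c2ccc(OC(C)(C)C(=O)Nc3ccc(Cl)c(C(F)(F)F)c3)c(OC)c2)cc1OC`. The change is chloro in place of nitro on an aromatic carbon, in words chloro in place of nitro on an aromatic carbon, ortho to a trifluoromethyl group and para to a large group.

The nearest measured change, fluoro in place of nitro on an aromatic carbon, gave an at least 1.8-fold lower number from compound 1 to compound 2 (0.26 log units; that floor lies within the scatter). The methyl change gave a step that the two limits leave unreadable from compound 1 to compound 3 and so offers no size to carry over. A move to a lower number is therefore expected in this assay, but only weakly, resting on compound 2 at 54800 nM. The smallest size that the fluoro step can have does not clear the scatter. The expected change is an at least 1.8-fold lower number from compound 3 to compound 4 (0.25 log units; that floor lies within the scatter). The estimate for compound 4 is 55000 nM, with an expected range of 20000 nM to 100000 nM.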

Compound 4, half-maximal inhibitory concentration: > 100000 nM
Compound 4 gave a limit, no number; the forecaster's own chance of this, stated with the estimate: 35%; middle value at least 1.8-fold (0.25 log units) from the limit.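

In this assay compound 4 gives > 100000 nM, which is a limit and not a number. Compound 3 also stands at a limit, so no step between compound 3 and compound 4 can be read: the limit of > 100000 nM in this assay, at which 3 of the 4 values shown sit.

The compounds shown leave open how far chloro in place of nitro moves the read-out on the core of compound 3.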